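The source may report more compounds than this note shows. Statements on the series, on what has been measured and on what is new or still open speak of the compounds shown alone.

Compound 1 `CC(NC(=O)C#Cc1ccc(NC(=O)Nc2cc(C(F)(F)F)ccc2Cl)cc1)c1ccccc1` gives 19000 nM
Compound 2 `CC(NC(=O)/C=C/c1ccc(NC(=O)Nc2ccc(Cl)c(C(F)(F)F)c2)cc1)c1ccccc1` gives 12200 nM

In a functional assay on HepG2 cells (Homo sapiens) for inhibition, read by MTT assay, with a stated time of 120 h (on this read-out higher numbers stand for weaker inhibition and lower numbers for stronger inhibition), compound 2 stands at 12200 nM within the scatter of compound 1, so these numbers do not separate the two. Compound 3 `CC1CN(C(=O)/C=C/c2ccc(NC(=O)Nc3ccc(Cl)c(C(F)(F)F)c3)cc2)CC(C)O1` has not yet been measured. It carries 2,6-dimethylmorpholin-4-yl in place of (1-phenylethyl)amino on a carbonyl carbon and keeps the rest of compound 2 unchanged. Among the compounds with values here, no measured pair shows a change at this place, so the data offer no guide to its direction or size. With compound 2 at 12200 nM as the only anchor, no step beyond the scatter is expected. The estimated step is a 1.2-fold higher number from compound 2 to compound 3 (0.09 log units; within the scatter) and should be read as tentative. In this assay the estimate for compound 3 is 15000 nM with an expected range from 6000 nM to 40000 nM on this read-out.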

Compound 3, half-maximal inhibitory concentration: 45900 nM
Beside the measured number, compound 3's estimate is 3.1-fold (0.49 log units) below it; measured number above the stated range.
By their numbers in this assay, from the lowest: compounds 2 and 1 (each within the scatter of the next); then compound 3.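

In this assay the place on the carbonyl carbon proves sensitive to what it carries: 2,6-dimethylmorpholin-4-yl in place of (1-phenylethyl)amino gives a 3.8-fold higher number from compound 2 to compound 3 (0.58 log units; beyond the scatter) and so favours the (1-phenylethyl)amino group on this core. Within the data shown here, this is the first change in the set that can be read as a step beyond the scatter, since compound 1 and compound 2 could not be separated and differ in more than one place. The exchange removes a hydrogen-bond donor and an aromatic ring and brings in a ring oxygen, but this single pair cannot tell which of these differences matters, and no measurement bearing on a cause is available.

The compounds shown leave open how an unsubstituted morpholine, a piperidine or a plain benzylamino group would fare at this place. They also leave open whether the same exchange would give a similar step on the core of compound 1.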